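Series notes: amine methylation on the saturated-linker core

The source may report more compounds than this note shows. Statements on the series, on what has been measured and on what is new or still open speak of the compounds shown alone.

Of the compounds shown here, two have numbers so far in an assay for binding affinity to Neuronal acetylcholine receptor; alpha4/beta2 (Rattus norvegicus); a lower number here means a stronger inhibitor, a higher number a weaker inhibitor. Compound 1 `CN1CCCC1COc1cnc(Cl)c(/C=C/c2cccnc2)c1` gives 0.088 nM. For the measured compounds named here, compound 2 `Clc1ncc(OCC2CCCN2)cc1CCc1ccncc1` gives 0.011 nM, the lowest of the two numbers; compound 1 stands above it by a distance beyond the usual scatter, but the two differ in several places at once, so the pair yields no single step to lean on.

Compound 3 `CN1CCCC1COc1cnc(Cl)c(CCc2ccncc2)c1` is the next one to be measured in this assay. Relative to compound 2 the change is methyl in place of hydrogen on an amine nitrogen in a ring, with the rest of the structure kept.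

Going by the values given here, no measured pair shows this one change in isolation, so the expected size rests only on the two values above. The expectation is a modest rise in the number, small enough that it may still fall within the scatter; a step from compound 2 to compound 3 of about a 3.6-fold higher number from compound 2 to compound 3 (0.56 log units; beyond the scatter) is estimated. For compound 3 the estimated value in this assay is 0.04 nM, with a range from 0.01 nM to 0.2 nM.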

Compound 3, inhibition constant: 0.023 nM
For compound 3 the middle estimate is 1.7-fold (0.24 log units) above the measured one; the range from low to high includes it.
By their numbers in this assay, from the lowest: compound 2; then compound 3; then compound 1.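

The pair of compound 2 and compound 3 gives the series its first step with a single change. In this assay, going from pyrrolidin-2-yl to 1-methylpyrrolidin-2-yl produces a 2.1-fold higher number from compound 2 to compound 3 (0.32 log units; beyond the scatter), so the amine nitrogen in the ring accepts a methyl with only a modest rise in the number, though the rise lies beyond the scatter. Nothing available explains the size of this step.

This single pair cannot show whether the same step holds on the core of compound 1, so the result stays tied to the saturated-linker core of compound 2 and compound 3. Also open, as far as these compounds go, is how the number responds to an ethyl or a longer chain on the same nitrogen.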